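A few compounds are considered here, and "the series" means these few. Any claim that something is new, unique, unknown or untested is made for them only; others in the source may bear on it.

Compound 1 `CCSc1sc(-n2nc(C)c(Cc3ccccc3[N+](=O)[O-])c2C(=O)O)nc1-c1ccc(Cl)c(Cl)c1`: 59000 nM
Compound 2 `Cc1c(-c2cc(Cl)cc(Cl)c2)c(C(=O)O)nn1-c1nc(-c2ccc3nccn3c2)c(SC(C)C)s1`: "not active" (no number reported)
Compound 3 `Cc1nn(-c2nc(-c3ccc(Cl)c(Cl)c3)c(SC(C)C)s2)c(C(=O)O)c1-c1ccc(C(F)(F)F)cc1`: 3500 nM

Of the compounds shown here, three have been measured in a functional assay on BJAB cells (Homo sapiens) for antiproliferative activity, with a stated time of 4 days; on this read-out lower numbers stand for an effect already at smaller amounts and higher numbers for an effect only at larger amounts of compound. Compound 1 gives 59000 nM, and compound 3 gives 3500 nM. Compound 2 stands apart from both: in this assay compound 2 is reported as "not active" (no number reported), and no single number is given for it, so its place on the scale of the other two cannot be fixed.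

Compound 4 `Cc1oncc1-c1nc(-n2nc(C(=O)O)c(-c3cc(Cl)cc(Cl)c3)c2C)sc1SC(C)C` is not yet measured. It is derived from compound 2 by one change: a group of 6 heavy atoms (4 carbon, 1 nitrogen, 1 oxygen; one five-membered aromatic ring with 2 hetero atoms) in place of a group of 9 heavy atoms (7 carbon, 2 nitrogen; one five-membered aromatic ring with 2 hetero atoms, one six-membered aromatic ring with 1 hetero atom), on an aromatic carbon. Within the data shown here, no step between measured compounds exists that would show what this change does, and the values of compound 1 and compound 3 differ from one another in several places at once, so they offer no direct guide either.

On these data alone, since compound 2 has no number, no step can be expected in any direction; the only anchor is that the measured numbers span a wide range, and a small heteroaryl group in place of a large one on this position of the shared core remains untested. Compound 4 is therefore estimated at 20000 nM, within a range from 4000 nM to 100000 nM, with a real chance that this assay again reports no number.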

Compound 4, half-maximal effective concentration: > 44000 nM
Compound 4: no number, only a limit (the forecaster's own chance of this, stated with the estimate: 40%); middle value at least 2.2-fold (0.34 log units) from the limit.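

Neither compound 2 nor compound 4 has a number in this assay so no step can be read between them. Compound 4 gives only a limit (> 44000 nM). The compounds shown leave open whether the 5-methyl-1,2-oxazol-4-yl group, in place of the larger group of compound 2, changes the result at all.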